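Bromo in place of fluoro in compound 3

The compounds below may be only part of what the source reports. "The series", "measured", "known", "first", "only" and "open" are said of these compounds alone.

Measured in a functional assay on HepG2 cells (Homo sapiens) for cytotoxicity, read by MTT assay, with a stated time of 24 h; a higher number here means a weaker inhibitor, a lower number a stronger inhibitor:
- compound 1 `O=C1/C(=C/c2cccnc2)CN(S(=O)(=O)c2ccccc2)C/C1=C\c1ccccc1F`: 8210 nM
- compound 2 `O=C1/C(=C/c2cccnc2)CN(S(=O)(=O)c2ccc([N+](=O)[O-])cc2)C/C1=C\c1ccccc1F`: 12800 nM
- compound 3 `O=C1/C(=C/c2cccnc2)CN(S(=O)(=O)c2ccc(F)cc2)C/C1=C\c1ccccc1F`: 15600 nM

On these numbers, compound 3 cannot be told apart from the other two, since all the steps stay within the usual scatter. Those steps are a 1.9-fold higher number from compound 1 to compound 3 (0.28 log units; within the scatter) and a 1.2-fold higher number from compound 2 to compound 3 (0.09 log units; within the scatter). Compound 4 `O=C1/C(=C/c2cccnc2)CN(S(=O)(=O)c2ccc(Br)cc2)C/C1=C\c1ccccc1F` has bromo in place of fluoro on an aromatic carbon, para to a large group (bromo in place of fluoro on an aromatic carbon). The same place has already been changed in a 1.6-fold higher number from compound 1 to compound 2 (0.19 log units; within the scatter), which also stayed within the scatter. No step beyond the scatter is therefore expected in this assay, and the expected step is a 1.3-fold lower number from compound 3 to compound 4 (0.11 log units; within the scatter). For compound 4 the estimated value is 12000 nM, with an expected range of 6000 nM to 24000 nM.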

Compound 4, half-maximal inhibitory concentration: 8700 nM
Beside the measured number, compound 4's estimate is 1.4-fold (0.14 log units) above it; measured number inside the range.
By their numbers in this assay, from the lowest: compounds 1, 4, 2 and 3 (each within the scatter of the next).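

In this assay, bromo at this position behaves like the three groups before it, whether it replaces fluoro (a 1.8-fold lower number from compound 3 to compound 4 (0.25 log units; within the scatter)), nitro (a 1.5-fold lower number from compound 2 to compound 4 (0.17 log units; within the scatter)) or hydrogen (a 1.1-fold higher number from compound 1 to compound 4 (0.03 log units; within the scatter)). Hydrogen, nitro, fluoro and bromo now all lie within the scatter of one another, so none of these four can be ranked above another at this position. No measurement bearing on this result is available to explain it. On these data alone, whether an amine or a carboxylic acid at this position would give a step beyond the scatter remains open.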